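This account rests on a few compounds, and the source may have more. Where it says the series, first, only, none or still open, it means among the compounds named here.

Working notes on the cytotoxicity series.

Three compounds have been run in an ADME assay on A549 cells (Homo sapiens) for cytotoxicity, read by MTT assay, with a stated time of 72 h; a lower number here means a stronger inhibitor, a higher number a weaker inhibitor. Compound 1 `O=C(NNC(=O)c1ccccc1[N+](=O)[O-])c1ccc(-n2cccc2)cc1` gives 205000 nM in this assay. Compound 2 `CC(=O)N1N=C(c2ccc(-n3c(C)ccc3C)cc2)OC1c1ccccc1[N+](=O)[O-]` gives 182000 nM. Compound 3 `Brc1ccc(-c2nnc(-c3ccc(-n4cccc4)cc3)o2)cc1` gives 264000 nM. Of the three numbers compound 2 is the one at the low end, yet compound 1 and compound 3 both fall within the usual scatter of it, so the three cannot be told apart on these data; all three sit in the same weak range, and nothing yet separates the hydrazide, the acetylated oxadiazoline and the oxadiazole from one another.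

The step followed here is from compound 2 to compound 4 `CC(=O)N1N=C(c2ccc(-n3c(C)ccc3C)cc2)OC1c1ccccc1`. The change is hydrogen in place of nitro on an aromatic carbon. For the measured compounds named here, no pair of measured compounds differs in only one place, so there is no measured step to lean on for the size of this change. What the three numbers do show is that compounds of quite different build all land in the same weak band, which argues for no step beyond the scatter in this assay. Compound 4 is therefore expected to stay where compound 2 is, a step of a 1.1-fold higher number from compound 2 to compound 4 (0.04 log units; within the scatter). The estimate for compound 4 in this assay is 200000 nM, with a range from 100000 nM to 400000 nM.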

Compound 4, half-maximal inhibitory concentration: 198000 nM
The estimate for compound 4 lay 1.0-fold (0.00 log units) above the measured number; measured number inside the range.
By their numbers in this assay, from the lowest: compounds 2, 4, 1 and 3 (each within the scatter of the next).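

In this assay, the series now has its first step that differs in one place, a 1.1-fold higher number from compound 2 to compound 4 (0.04 log units; within the scatter), with hydrogen in place of nitro on an aromatic carbon, at the position ortho to a large group. The earlier compounds shown here could suggest only loosely, across different builds, that the numbers share one weak band; this pair shows directly that going from 2-nitrophenyl to phenyl on an otherwise identical structure, with the loss of all 3 heavy atoms of the nitro group, gives no step beyond the scatter, so in this pair the nitro group is not required for the number to stay in that band. Nothing at hand bears on the reason for this result.

The compounds shown leave open whether a different group at this same position, such as an amine, a carboxylic acid or a methoxy group, would also stay within the scatter of compound 2 or would give a real step. They also leave open whether hydrogen in place of nitro would read the same on the core of compound 1, which carries the same 2-nitrophenyl group on a different build.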